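Methoxy to isopropyl on two related cores

This account rests on a few compounds, and the source may have more. Where it says the series, first, only, none or still open, it means among the compounds named here.

Measured so far in a functional assay on MDA-MB-231 cells (Homo sapiens) for antiproliferative activity, read by MTT assay, with a stated time of 48 h; on this read-out lower numbers stand for stronger inhibition and higher numbers for weaker inhibition:
compound 1 `COc1ccc(/C=N/c2c(C#N)ncn2-c2ccc(F)cc2)cc1` gives 17100 nM;
compound 2 `CC(C)c1ccc(/C=N/c2c(C#N)ncn2-c2ccc(F)cc2)cc1` gives 20500 nM;
compound 3 `COc1ccc(C2N=C(C(N)=O)c3ncn(-c4ccc(F)cc4)c3N2)cc1` gives 1220 nM.

Compound 1 and compound 2 share one core and differ only in one group: isopropyl in place of methoxy on an aromatic carbon. This change gave a 1.2-fold higher number from compound 1 to compound 2 (0.08 log units; within the scatter), so the two numbers cannot be told apart on this read-out.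

Compound 3 is built on a different core. The difference between the two cores is not broken down here. Compound 3 carries the same methoxy group as compound 1, and its number is the lowest of the three, standing well apart from both compound 1 and compound 2.

Compound 4 `CC(C)c1ccc(C2N=C(C(N)=O)c3ncn(-c4ccc(F)cc4)c3N2)cc1` has not yet been measured. It relates to compound 3 exactly as compound 2 relates to compound 1: isopropyl in place of methoxy on an aromatic carbon. The place of the change is the same in both pairs, so this is the same change made on a second core.

Because the step of a 1.2-fold higher number from compound 1 to compound 2 (0.08 log units; within the scatter) stayed within the scatter on the first core, the expectation is that the same change on the core of compound 3 will also leave the number about where it is, that is, a step of a 1.2-fold higher number from compound 3 to compound 4 (0.09 log units; within the scatter) is expected. That rests on a single earlier pair, so the range is kept wide. Compound 4 is therefore estimated at 1500 nM, with a range from 600 nM to 4000 nM.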

Compound 4, half-maximal inhibitory concentration: 2290 nM
For compound 4 the middle estimate is 1.5-fold (0.18 log units) below the measured one, and the stated range covers the measured number.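

In this assay, replacing 4-methoxyphenyl with 4-isopropylphenyl on the second core gave a 1.9-fold higher number from compound 3 to compound 4 (0.27 log units; within the scatter), so on this core too the change leaves a step too small to read. Set side by side, the two results agree: the same change on two cores in this assay, a 1.2-fold higher number (0.08 log units; within the scatter) from compound 1 to compound 2 and a 1.9-fold higher number (0.27 log units; within the scatter) from compound 3 to compound 4, 1.6-fold (0.19 log units) apart, within the scatter of two such steps

This shows that, on these two cores, the swap from methoxy to isopropyl carried over from one core to the other as a step inside the usual noise of the measurement, and the large gap between the two cores is left standing whichever of these groups is present. It does not show that the two groups are truly equivalent, since a small real difference could hide inside that noise, and two pairs cannot say whether the same would hold on a third core.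

On these data alone, both pairs compare only methoxy and isopropyl at one place on the ring, so what an amine, a carboxylic acid or a longer chain would do there remains open. Also open, as far as these compounds go, is which part of the difference between the two cores goes with the lower numbers of compound 3 and compound 4, since the cores differ in more than one place.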